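The source may report more compounds than this note shows. Statements on the series, on what has been measured and on what is new or still open speak of the compounds shown alone.

Compound 3 `CCc1nc(-c2cnc3ccc(-c4cccc(N)c4)cc3c2)no1` is followed in a functional assay on RD cells (Homo sapiens) for inhibition, read by luminescence and ATP content, with a stated time of 72 h; a higher number here means that more compound is tolerated, a lower number that less compound is tolerated. In this assay compound 3 gives only a limit, > 7400 nM. The other two measured compounds sit at that same limit. Compound 1 `CCOC(=O)c1cnc2ccc(-c3cccc(N)c3)cc2c1` gives in this assay the limit > 7400 nM. Compound 2 `CCOC(=O)c1cnc2ccc(-c3ccc(C(C)C)cc3)cc2c1` gives in this assay the limit > 7400 nM. So the whole picture is the limit of > 7400 nM in this assay, at which 3 of the 3 values shown sit, and the one recorded change, a step that the two limits leave unreadable from compound 1 to compound 3, cannot be read in size or in direction. Compound 4 `CCc1nc(-c2cnc3ccc(-c4ccc(N)c(Cl)c4)cc3c2)no1` has not been measured and differs from compound 3 in one place: 4-amino-3-chlorophenyl in place of 3-aminophenyl on an aromatic carbon. Going by the values given here, no measured step covers this change, and the only measured step is unreadable, so nothing among the measured compounds points to a shift in this assay in either direction beyond the scatter. Compound 4 is therefore expected to remain near the limit, with an expected step that the limit leaves unreadable from compound 3 to compound 4 that carries no real weight. As an estimate, compound 4 in this assay is expected at 10000 nM, within 3000 nM to 30000 nM.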

Compound 4, half-maximal cytotoxic concentration: > 7400 nM
Compound 4: a limit, no number; the forecaster's own chance of this, stated with the estimate: 80%; the middle value lies beyond the limit too.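

Compound 3 and compound 4 both give only a limit in this assay, so the step between them cannot be read in size or direction: the limit of > 7400 nM in this assay, at which 4 of the 4 values shown sit.

The compounds shown leave open where any true half-maximal cytotoxic concentration lies, and whether 4-amino-3-chlorophenyl in place of 3-aminophenyl changes it at all.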